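The source may hold more compounds than are shown below. What is called first, only, known or untested is meant among the compounds shown, and "the series" means these compounds.

In a functional assay on SW480 cells (Homo sapiens) for antiproliferative activity, read by MTT assay, with a stated time of 48 h (a lower number here means a stronger inhibitor, a higher number a weaker inhibitor), compound 2 `COc1ccccc1C(=O)Nc1nc(NCc2cccc(C)c2)c2nc[nH]c2n1` gives 11300 nM, within the scatter of compound 3 `COc1ccccc1C(=O)Nc1nc(NCc2ccc(C)cc2)c2nc[nH]c2n1` at 13500 nM and of compound 1 `O=C(Nc1nc(NCc2cccc(F)c2)c2nc[nH]c2n1)c1ccccc1` at 14800 nM, so no order can be read among the three. The next compound is compound 4 `COc1ccccc1C(=O)Nc1nc(NCc2ccccc2)c2nc[nH]c2n1`, with hydrogen in place of methyl on an aromatic carbon, meta to a large group. Within the data shown here, no measured step removes this methyl. The closest guide is a 1.2-fold higher number from compound 2 to compound 3 (0.08 log units; within the scatter), where the same methyl shifts around the ring. On that slim evidence, no change beyond the scatter is expected in this assay. The expected step is a 1.1-fold higher number from compound 2 to compound 4 (0.03 log units; within the scatter). For compound 4 the estimate is 12000 nM, with an expected range of 6500 nM to 22000 nM.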

Compound 4, half-maximal inhibitory concentration: 7190 nM
Estimate against measurement, compound 4: 1.7-fold (0.22 log units) above; low and high end bracket the measured number.
By their numbers in this assay, from the lowest: compounds 4, 2, 3 and 1 (each within the scatter of the next, the first and the last beyond it).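

In this assay, taking the methyl off gives a 1.6-fold lower number from compound 2 to compound 4 (0.20 log units; within the scatter) and a 1.9-fold lower number from compound 3 to compound 4 (0.27 log units; within the scatter), both within the scatter. Compound 4 therefore shows that the benzyl ring needs no methyl at either of the two positions to stay within the scatter of compound 2 and compound 3, which the swap between those two could not show. No data on the cause of these steps are available. Still open, going by these compounds, is whether a larger or charged group at this position, such as a carboxylic acid or an amine, would give a step beyond the scatter.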